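From compound 1 to compound 3: methyl on the amide nitrogen

A few compounds are considered here, and "the series" means these few. Any claim that something is new, unique, unknown or untested is made for them only; others in the source may bear on it.

- Compound 1 `N#Cc1ccc(NC(=O)c2cc(F)ccc2O)cc1`: 1420 nM
- Compound 2 `O=C(Nc1ccc([N+](=O)[O-])cc1)c1cc(F)ccc1O`: 520 nM

In a functional assay on HL-60 cells (Homo sapiens) for cytotoxicity, read by luminescence and CellTiter-Glo, with a stated time of 3 days (on this read-out lower numbers stand for stronger inhibition and higher numbers for weaker inhibition), compound 1, at 1420 nM, has the higher number of the two measured compounds, and compound 2 gives 520 nM. Compound 3 `CN(C(=O)c1cc(F)ccc1O)c1ccc(C#N)cc1` has not yet been measured. It differs from compound 1 by methyl in place of hydrogen on an amide-type nitrogen.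

Among the compounds with values here, the only measured step is a 2.7-fold lower number from compound 1 to compound 2 (0.44 log units; beyond the scatter). That step is nitro in place of cyano on an aromatic carbon, so it does not touch the amide nitrogen and bears on the new change only as a guide to size. No measurement here shows what replacing the amide hydrogen does. A higher number in this assay is therefore expected as a judgement only, with a step somewhat larger than the measured one and considerable uncertainty. The estimated step is a 3.2-fold higher number from compound 1 to compound 3 (0.50 log units; beyond the scatter). For compound 3 the expected value is 4500 nM, with an estimated range of 1500 nM to 15000 nM.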

Compound 3, half-maximal inhibitory concentration: > 10000 nM
Compound 3: no number, only a limit (the forecaster's own chance of this, stated with the estimate: 15%); middle value at least 2.2-fold (0.34 log units) from the limit.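

In this assay compound 3 gives > 10000 nM, which is a limit of the assay and not a number: the limit of > 10000 nM in this assay, at which 1 of the 3 values shown sits.

Within the data shown here, the change at the amide nitrogen gives an at least 7.0-fold higher number from compound 1 to compound 3 (0.84 log units; beyond the scatter), and it is the first evidence at this position, since the earlier step, a 2.7-fold lower number from compound 1 to compound 2 (0.44 log units; beyond the scatter), left the amide hydrogen in place and changed only the group on an aromatic carbon. It also runs in the opposite direction to that earlier step, so this position is one where methyl in place of hydrogen, a single added carbon with no hydrogen-bond donor or acceptor of its own, is enough to carry the number to the limit of the assay.

The compounds shown leave open whether ethyl, a longer chain or an acetyl group on the same nitrogen would behave as methyl does, and whether methyl there would have the same outcome with the nitro group of compound 2. They also leave open the real size of the step, which can be read only as a minimum.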